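A Repeated Ester-for-Trifluoromethyl Swap on Two Related Cores

A few compounds are considered here, and "the series" means these few. Any claim that something is new, unique, unknown or untested is made for them only; others in the source may bear on it.

Compound 1 `NS(=O)(=O)NCC1CCN(c2cc(-c3ccc(C(F)(F)F)cc3)ncn2)CC1` was tested in a functional assay on HT-29 cells (Homo sapiens) for antiproliferative activity, read by sulforhodamine B assay, with a stated time of 48 h (a higher number here means a weaker inhibitor of growth, a lower number a stronger inhibitor of growth), and gives 29100 nM. Compound 2 `COC(=O)c1ccc(-c2cc(N3CCC(CNS(N)(=O)=O)CC3)ncn2)cc1` carries methoxycarbonyl in place of trifluoromethyl on an aromatic carbon; in this assay compound 2 gives 22900 nM, and that single change made the step of a 1.3-fold lower number from compound 1 to compound 2 (0.10 log units; within the scatter). Compound 3 `NS(=O)(=O)NCCC1CCN(c2cc(-c3ccc(C(F)(F)F)cc3)ncn2)CC1` has a different core, which differs from the core of compound 1 by (sulfamoylamino)methyl in place of sulfamoylamino on a saturated chain carbon bound to a saturated ring carbon; in this assay compound 3 gives 22600 nM, the step being a 1.3-fold lower number from compound 1 to compound 3 (0.11 log units; within the scatter). Among the compounds with values here, the three numbers lie close together, so no compound stands apart from the others.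

Compound 4 `COC(=O)c1ccc(-c2cc(N3CCC(CCNS(N)(=O)=O)CC3)ncn2)cc1` has not yet been measured. Within the data shown here, it differs from compound 3 by methoxycarbonyl in place of trifluoromethyl on an aromatic carbon, and the two descriptions of the place where this happens read the same word for word, so this is the same change as the one from compound 1 to compound 2, now made on the other core. The step from compound 3 to compound 4 is expected to be a 1.3-fold lower number from compound 3 to compound 4 (0.11 log units; within the scatter), because the same swap earlier gave a 1.3-fold lower number from compound 1 to compound 2 (0.10 log units; within the scatter). Compound 4 is therefore estimated to give about 17500 nM, expected to fall between 9000 nM and 35000 nM.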

Compound 4, concentration for 50% growth inhibition: 19600 nM
For compound 4 the middle estimate is 1.1-fold (0.05 log units) below the measured one; the measured number falls inside the stated range.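

In this assay, within the data shown here, methoxycarbonyl in place of trifluoromethyl gives a 1.2-fold lower number from compound 3 to compound 4 (0.06 log units; within the scatter), and this step agrees with the earlier one on the other core: the same change on two cores in this assay, a 1.3-fold lower number (0.10 log units; within the scatter) from compound 1 to compound 2 and a 1.2-fold lower number (0.06 log units; within the scatter) from compound 3 to compound 4, 1.1-fold (0.04 log units) apart, within the scatter of two such steps The change of side chain, (sulfamoylamino)methyl in place of sulfamoylamino, gives a 1.2-fold lower number from compound 2 to compound 4 (0.07 log units; within the scatter) with the ester in place, and it also agrees with its earlier counterpart: the same change on two cores in this assay, a 1.3-fold lower number (0.11 log units; within the scatter) from compound 1 to compound 3 and a 1.2-fold lower number (0.07 log units; within the scatter) from compound 2 to compound 4, 1.1-fold (0.04 log units) apart, within the scatter of two such steps Both changes therefore read the same on either core, but every step lies within the scatter, so this agreement shows only that neither change gave a measurable effect in these four compounds, not that a real effect carries from one core to another.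

As far as these compounds go, it remains open whether a carboxylic acid or a nitrile in the place of the ester, or a longer chain bearing the sulfamoylamino group, would give a step beyond the scatter. Only such a step could test whether a change carries across these cores with its size intact.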